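The compounds below may be only part of what the source reports. "The series", "measured", "known", "first", "only" and "open" are said of these compounds alone.

Measured compounds:
- compound 1 `Nc1sc(-c2ccc(Cl)cc2)c(-c2ccc(Cl)cc2)c1C(=O)NC1CCC(O)CC1`: 250 nM
- compound 2 `CCN(CC)CCNC(=O)Nc1sc(-c2ccc(Cl)cc2)c(-c2ccc(Cl)cc2)c1C(=O)NC1CC1`: "not determined" (no result reported)

Going by the values given here, compound 1 is the only member of the series with a number in a functional assay on A549 cells (Homo sapiens) for inhibition, read by sulforhodamine B assay, with a stated time of 72 h (on this read-out higher numbers stand for weaker inhibition and lower numbers for stronger inhibition), where compound 1 gives 250 nM. Among the compounds with values here, compound 2 was taken into the same assay but no result was reported for it, so nothing can be set beside compound 1 and no step between measured compounds is available.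

The next compound, compound 3 `Nc1sc(-c2ccc(Cl)cc2)c(-c2ccc(Cl)cc2)c1C(=O)NCc1ccccc1`, keeps the shared core of compound 1 and differs in one place: benzyl in place of 4-hydroxycyclohexyl on an amide-type nitrogen. Within the data shown here, with no measured step to lean on, the size of the change in this assay can only be guessed from the structural change itself. The expectation is a small shift toward weaker inhibition, of a size that may not clear the scatter of repeated measurements, with a wide range to either side.

Compound 3 is therefore expected to give 400 nM in this assay, with a range from 100 nM to 1600 nM. That estimate means a step of a 1.6-fold higher number from compound 1 to compound 3 (0.20 log units; within the scatter), expected rather than known.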

Compound 3, half-maximal inhibitory concentration: 16300 nM
For compound 3 the middle estimate is 41-fold (1.61 log units) below the measured one; measured number above the stated range.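

In this assay the exchange of 4-hydroxycyclohexyl for benzyl on the amide-type nitrogen gives a 65-fold higher number from compound 1 to compound 3 (1.81 log units; beyond the scatter), a large step beyond the scatter, with the shared core left as it is. The group on this nitrogen therefore matters for the read-out, which compound 1 alone could not show. Both groups hold 7 heavy atoms and one six-membered ring, so heavy-atom count and ring size do not separate them; they differ in that 4-hydroxycyclohexyl is non-aromatic with 1 hydrogen-bond donor and 1 hydrogen-bond acceptor, while benzyl is aromatic with neither, and no measurement here ties the step to either difference.

Still open, going by these compounds, is whether the hydroxyl or the ring type accounts for the step: plain cyclohexyl and a benzyl carrying a hydroxyl on its ring would separate the two. Also open, on these data alone, is how an amine or a carboxylic acid in place of the hydroxyl would read in this assay, and whether a longer chain between the amide-type nitrogen and the ring would change the picture.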